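From Ethoxycarbonyl to Carbamoyl: Expecting Compound 4

The source may report more compounds than this note shows. Statements on the series, on what has been measured and on what is new or still open speak of the compounds shown alone.

Measured so far:
compound 1, `CCOC(=O)c1ccc(/N=N/N(C)CC)cc1`, gives 3.01;
compound 2, `CCOC(=O)c1nc(C)[nH]c1/N=N/N(C)C`, gives 3.35;
compound 3, `CCOC(=O)c1ccc(/N=N/N(C)CC(C)C)cc1`, gives 2.8.

All three numbers come from a functional assay on L1210 cells (Mus musculus) for antiproliferative activity; a lower number here means a less potent compound, a higher number a more potent compound, by a factor of ten per unit of this negative logarithm. Compound 1 holds the second highest of the three. Its nearest neighbour is compound 3, and the step of a number 0.21 log units lower from compound 1 to compound 3 (within the scatter) lies within the scatter, so the two cannot be ordered. Compound 2 stands apart: its value sits beyond the scatter above that of compound 1.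

Compound 4, `CCN(C)/N=N/c1ccc(C(N)=O)cc1`, has not yet been measured. It differs from compound 1 in a single place: amino in place of ethoxy on a carbonyl carbon.

For the measured compounds named here, none of the measured steps touches this part of the molecule. Going by the values given here, the only step known, from compound 1 to compound 3, alters the saturated chain on the amine nitrogen at the far side of the shared core, and it stays within the scatter. There is thus no measured guide to what trading ethoxy for amino on the carbonyl carbon does in this assay. In that situation the plainest expectation is a step of no size beyond the scatter, with a wide range to cover the absence of evidence.

For compound 4 the expected value is 2.9, in a range from 2.3 to 3.5, which means an expected step of a number 0.11 log units lower from compound 1 to compound 4 (within the scatter).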

Compound 4, logarithm of the reciprocal of the active concentration, log(1/C): 3.66
Compound 4: the middle estimate sits 0.76 log units below what was measured, outside the stated range (above it).
By their numbers in this assay, from the lowest: compounds 3 and 1 (each within the scatter of the next); then compound 2; then compound 4.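

Changing the group on the carbonyl carbon matters in this assay: amino in place of ethoxy gives a number 0.65 log units higher from compound 1 to compound 4 (beyond the scatter) and puts compound 4 above the other compounds shown. For the compounds shown here, the only earlier step that changes one place, a number 0.21 log units lower from compound 1 to compound 3 (within the scatter), concerns the saturated chain on the amine nitrogen and stays within the scatter, so this is the first single change here to move the number by more than the scatter. The swap also alters two counted features at once: ethoxy has 3 heavy atoms and no hydrogen-bond donor, whereas amino has 1 heavy atom and 1 hydrogen-bond donor, and this single pair of compounds cannot show which of these differences goes with the higher number.

Other groups on the same carbonyl carbon would help to separate those features: methoxy, methylamino, dimethylamino or a hydroxyl that makes a carboxylic acid remain open, as does whether amino gives a similar step on a different amine chain. The compounds and data shown offer no measured explanation for the higher number of compound 4.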